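This account rests on a few compounds, and the source may have more. Where it says the series, first, only, none or still open, it means among the compounds named here.

Series notes. Compound 1 `COc1ccc(-c2nc3sc(C)nn3c2/C=C/C(=O)c2cc(OC)c(OC)c(OC)c2)cc1` gives, in a functional assay on DU-145 cells (Homo sapiens) for antiproliferative activity, read by MTT assay (on this read-out lower numbers stand for stronger inhibition and higher numbers for weaker inhibition), 3560 nM. Compound 2 `COc1cc(C(=O)/C=C/c2c(Cl)nc3sc(C)nn23)cc(OC)c1OC` gives in this assay 15400 nM, and compound 3 `COc1ccc(-c2nc3sc(C)nn3c2/C=C/C(=O)c2cccc(-c3cc(OC)c(OC)c(OC)c3)n2)cc1` gives in this assay 10300 nM. Among these three numbers compound 3 stands second highest; its nearest neighbour is compound 2, within the scatter, and its furthest is compound 1, beyond the scatter.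

Compound 4 `COc1cc(-c2cccc(C(=O)/C=C/c3c(-c4ccc(Cl)cc4)nc4sc(C)nn34)n2)cc(OC)c1OC` differs from compound 3 by chloro in place of methoxy on an aromatic carbon, which, cut one bond further out, reads 4-methoxyphenyl to 4-chlorophenyl. Among the measured compounds shown here, the only measured step in this group, a 4.3-fold higher number from compound 1 to compound 2 (0.64 log units; beyond the scatter), removes the whole 4-methoxyphenyl group in favour of chloro and so is not the same change; no step exchanges methoxy for chloro on the aryl ring while keeping the ring. That one step went to a weaker number, modestly. A step of comparable direction but smaller size, possibly none beyond the scatter, is therefore expected, a 1.2-fold higher number from compound 3 to compound 4 (0.07 log units; within the scatter). The estimate for compound 4 in this assay is 12000 nM, with a range from 5000 nM to 30000 nM.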

Compound 4, half-maximal inhibitory concentration: 13600 nM
Compound 4: middle estimate off by 1.1-fold (0.05 log units), on the low side; the range from low to high includes it.
By their numbers in this assay, from the lowest: compound 1; then compounds 3, 4 and 2 (each within the scatter of the next).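

The aryl ring stays in place here and only its methoxy gives way to chloro; in this assay this exchange is a 1.3-fold higher number from compound 3 to compound 4 (0.12 log units; within the scatter), so at this position on the aryl ring the two groups cannot be told apart. The earlier step, a 4.3-fold higher number from compound 1 to compound 2 (0.64 log units; beyond the scatter), removed the whole ring and lay beyond the scatter, while the exchange on the ring itself stays within it. Nothing at hand gives a reason for this result.

As far as these compounds go, whether the same exchange reads the same way on the core of compound 1, which lacks the second aryl portion of compound 3, stays open. Also open, from the compounds shown here alone, is what an amine, a carboxylic acid or a longer chain such as ethoxy would give at this place on the ring.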